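Carboxyphenyl for bromo on a TRPM8 antagonist scaffold

The compounds below may be only part of what the source reports. "The series", "measured", "known", "first", "only" and "open" are said of these compounds alone.

Measured compounds:
- compound 1 `O=C(C(Nc1ccccc1F)c1ccc(Br)cc1)N1CCC[C@H]1c1ccccc1F`: 9 nM
- compound 2 `O=C(C(Nc1ccccc1F)c1ccc2c(c1)CCO2)N1CCC[C@H]1c1ccccc1F`: 14 nM

Compound 1 gives the lower of the two numbers in an assay on HEK293 cells for antagonist activity at transient receptor potential M8 protein (Canis lupus familiaris), read by fluorescence and calcium flux, with a stated time of 5 min (on this read-out higher numbers stand for weaker inhibition and lower numbers for stronger inhibition), with compound 2 nearest to it; the step of a 1.6-fold higher number from compound 1 to compound 2 (0.19 log units; within the scatter) lies within the scatter, so the two cannot be ordered. That single measured step swaps the bromophenyl portion for a fused bicyclic group of modest size on the carbon between the carbonyl and the anilino nitrogen.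

Compound 3 `O=C(O)c1ccc(-c2ccc(C(Nc3ccccc3F)C(=O)N3CCC[C@H]3c3ccccc3F)cc2)cc1` differs from compound 1 by 4-carboxyphenyl in place of bromo on an aromatic carbon. Among the measured compounds shown here, the only measured step that bears on it is the one from compound 1 to compound 2, which changed the same region of the core and left the number essentially unchanged. The change to compound 3 is larger in what enters, so that step is only a loose guide. Compound 3 is therefore expected to move by a 3.3-fold higher number from compound 1 to compound 3 (0.52 log units; beyond the scatter) in this assay, toward a weaker number but with wide uncertainty. The estimate for compound 3 is 30 nM, within a range of 5 nM to 200 nM.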

Compound 3, half-maximal inhibitory concentration: 56 nM
For compound 3 the middle estimate is 1.9-fold (0.27 log units) below the measured one; measured number inside the range.
By their numbers in this assay, from the lowest: compounds 1 and 2 (each within the scatter of the next); then compound 3.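

Putting 4-carboxyphenyl in place of bromo gives, in this assay, a 6.2-fold higher number from compound 1 to compound 3 (0.79 log units; beyond the scatter), so this position on an aromatic carbon, para to a large group, does respond to what is placed there, which the earlier step, a 1.6-fold higher number from compound 1 to compound 2 (0.19 log units; within the scatter), did not show. The shift is modest for a change that replaces a single bromine with a group of 9 heavy atoms carrying a six-membered aromatic ring and a hydrogen-bond donor, and compound 3 still gives 56 nM as a measurable inhibition value, so the position accepts this much larger group at a limited cost in this read-out. Nothing available here explains the rise in the number, and the step alone cannot assign it to any feature of the entering group.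

The compounds shown leave open how much of the step belongs to the added phenyl ring and how much to the carboxylic acid on it, a question that a plain phenyl, a methyl ester or a primary amide at the same place would address. They also leave open how a carboxylic acid set directly on the ring in place of bromo, or an aminomethyl group there, would compare.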